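Coumarin hydrazides: propoxy to bromobenzyloxy on the aromatic oxygen

The source may hold more compounds than are shown below. What is called first, only, known or untested is meant among the compounds shown, and "the series" means these compounds.

The series is followed in a functional assay on HeLa cells (Homo sapiens) for cytotoxicity, read by MTT assay, with a stated time of 72 h; a lower number here means a stronger inhibitor, a higher number a weaker inhibitor. Compound 3 `CCCOc1ccc2cc(C(=O)NN)c(=O)oc2c1` sits at the weak end of the numbers shown: in this assay compound 3 gives > 100000 nM, which is a limit of the assay and not a number (the limit of > 100000 nM in this assay, at which 1 of the 3 values shown sits). Among the measured compounds shown here, compound 2 `CCN(CC)c1ccc2cc(C(=O)NN)c(=O)oc2c1` gives 5480 nM, and the step of an at least 18-fold higher number from compound 2 to compound 3 (1.26 log units; beyond the scatter) is the only measured step in the set. Compound 1 `O=C(NCCO)c1cc2ccc(OCc3cccc(Br)c3)cc2oc1=O` gives 17600 nM and already carries the 3-bromobenzyl group on a saturated chain carbon bound to an oxygen on an aromatic ring.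

Compound 4 `NNC(=O)c1cc2ccc(OCc3cccc(Br)c3)cc2oc1=O` is compound 3 with 3-bromophenyl in place of ethyl on a saturated chain carbon bound to an oxygen on an aromatic ring. For the measured compounds named here, no measured step covers this exact change; the step from compound 2 to compound 3 bears on it only in that exchanging the group at that aromatic position moved the number far beyond the scatter, and compound 1 shows that the 3-bromobenzyl group is compatible with a measurable number. Compound 4 is therefore expected to come off the limit, with an estimated step of an at least 3.3-fold lower number from compound 3 to compound 4 (0.52 log units; beyond the scatter). The estimate for compound 4 is 30000 nM, in the range 8000 nM to 150000 nM.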

Compound 4, half-maximal inhibitory concentration: > 100000 nM
Compound 4 was reported as a limit; the forecaster's own chance of this, stated with the estimate: 25%; middle value at least 3.3-fold (0.52 log units) away from the limit.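

In this assay compound 4 gives a limit of the assay and not a number (> 100000 nM). Exchanging propyl for 3-bromobenzyl on the oxygen therefore brings no readable gain, and the step between compound 3 and compound 4 cannot be read because both values rest at the same limit: the limit of > 100000 nM in this assay, at which 2 of the 4 values shown sit.

With the 3-bromobenzyl group held in place, amino in place of 2-hydroxyethyl on an amide-type nitrogen gives an at least 5.6-fold higher number from compound 1 to compound 4 (0.75 log units; beyond the scatter) and so shows that the 3-bromobenzyl group alone does not secure a measurable number.

Open, as far as these compounds go, is whether a longer chain such as 3-hydroxypropyl on that amide-type nitrogen keeps a measurable number. Also open, from the compounds shown here alone, is whether a smaller amine such as dimethylamino on the aromatic carbon stays close to compound 2 in this series.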